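The source may report more compounds than this note shows. Statements on the series, on what has been measured and on what is new or still open speak of the compounds shown alone.

Working notes on the series.

Two members of the series have been taken through an ADME assay on J774 cells (Mus musculus) for cytotoxicity, read by MTT assay, with a stated time of 48 h, tested at 150 ug/mL; on this read-out lower numbers stand for a stronger effect and higher numbers for a weaker effect at the one concentration tested. Compound 1 `O=C(N/N=C/c1ccccc1Cl)c1cnccn1` gives 69% in this assay , and compound 2 `O=C(N/N=C/c1cccc(O)c1)c1cnccn1` gives 88%. Among the two numbers compound 1 stands lowest; compound 2 sits higher by a gap that is beyond the scatter of this assay . Among the measured compounds shown here, no pair of measured compounds differs in a single place, so no measured step is available to guide the change considered next.

Compound 3 `N#Cc1ccccc1/C=N/NC(=O)c1cnccn1` is the next candidate for this assay . Relative to compound 1 it carries cyano in place of chloro on an aromatic carbon. For the measured compounds named here, the series holds no measured step for a change of this kind, so the direction cannot be read from the data; the expectation is a small shift from compound 1 that may well fall within the usual scatter, with a mild lean toward a weaker effect. The step expected in this assay is a number 5 percentage points higher from compound 1 to compound 3 (within the scatter). Compound 3 is accordingly estimated to give 74% in this assay , with a range from 58% to 90%.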

Compound 3, a percentage reported as activity, at one concentration (the size of the read-out at that concentration, not a potency): 70%
Beside the measured number, compound 3's estimate is 4 percentage points above it; low and high end bracket the measured number.
By their numbers in this assay, from the lowest: compounds 1 and 3 (each within the scatter of the next); then compound 2.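

In this assay the series now has its first measured step between compounds that differ in one place: cyano in place of chloro on an aromatic carbon, ortho to a large group, gives a number 1 percentage points higher from compound 1 to compound 3 (within the scatter). At this position, the chloro can therefore give way to a cyano, which brings a triple bond and a hydrogen-bond acceptor, with no shift in the read-out that stands clear of the scatter. Nothing measured on these groups speaks to why compound 1 and compound 3 read alike.

This single step leaves open whether an amine, a carboxylic acid or a methoxy group on the same aromatic carbon would also stay within the scatter of compound 1, or would move the read-out clearly in either direction. Among the compounds shown here, it also leaves open whether the exchange of chloro for cyano would read the same way at another carbon of the aromatic ring, as the series so far holds this change at one place only.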